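Fluoro for methyl in a cytotoxicity screen

The source may hold more compounds than are shown below. What is called first, only, known or untested is meant among the compounds shown, and "the series" means these compounds.

Measured compounds:
compound 1, `COc1cc(C#N)ccc1OCc1nnc(-c2ccc(C)cc2)o1`: > 100000 nM
compound 2, `COc1cc(C#N)ccc1OCc1nnc(-c2ccc(F)cc2)o1`: > 100000 nM
compound 3, `Cc1ccc(-c2nnc(COc3ccc(C#N)c(F)c3)o2)cc1`: > 100000 nM

In an ADME assay on MCF-10A cells (Homo sapiens) for cytotoxicity, read by MTT assay, with a stated time of 48 h (on this read-out higher numbers stand for weaker inhibition and lower numbers for stronger inhibition), compound 1 gives > 100000 nM, which is a limit of the assay and not a number. Compound 2 gives > 100000 nM, again a limit. Compound 3 gives > 100000 nM, also a limit.

Compound 2 differs from compound 1 by fluoro in place of methyl on an aromatic carbon. The step that the two limits leave unreadable from compound 1 to compound 2 cannot be read, since both compounds sit at the limit; this is the position described by the limit of > 100000 nM in this assay, at which 3 of the 3 values shown sit, where every value in the set stands.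

The cores of compound 1 and compound 3 differ in more than one place, and the difference between the two cores is not broken down here.

Compound 4, `N#Cc1ccc(OCc2nnc(-c3ccc(F)cc3)o2)cc1F`, is not yet measured. Among the measured compounds shown here, it differs from compound 3 by fluoro in place of methyl on an aromatic carbon, the same change as the one from compound 1 to compound 2, made on the core of compound 3 instead.

The expected step that the limit leaves unreadable from compound 3 to compound 4 rests on the fact that the same change left compound 1 and compound 2 both at the limit, a step that the two limits leave unreadable from compound 1 to compound 2, and on (the limit of > 100000 nM in this assay, at which 3 of the 3 values shown sit). Compound 4 is therefore expected to give 150000 nM in this assay, with a plausible range from 60000 nM to 400000 nM, most likely reported as a limit rather than a number.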

Compound 4, half-maximal inhibitory concentration: 84200 nM
For compound 4 the middle estimate is 1.8-fold (0.25 log units) above the measured one, within the range that was stated.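

Compound 3 gives > 100000 nM in this assay, which is a limit of the assay and not a number. The change from 4-methylphenyl to 4-fluorophenyl on this core gives an at least 1.1-fold lower number from compound 3 to compound 4 (0.07 log units; that floor lies within the scatter); this size is only a floor, and it does not establish that the change lowers the number at all, though a larger true step is not ruled out. Among the compounds shown here, the same change on the core of compound 1 gives a step that cannot be read, with both of its ends at a limit, so the two cores offer no pair of sizes to compare, and nothing here shows either that the change carries from one core to the other or that it fails to.

The compounds shown leave open how far this series reaches below the limit, with only compound 4 giving a number and the rest of the set standing at that limit: the limit of > 100000 nM in this assay, at which 3 of the 4 values shown sit. Also open is whether an amine or a carboxylic acid in place of the fluoro, or a longer chain in place of the methyl, would give a value clearly separated from that limit on either core.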